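This account rests on a few compounds, and the source may have more. Where it says the series, first, only, none or still open, it means among the compounds named here.

Measured so far: compound 1 `C#CCSc1nc(N/N=C/c2cc(OC)c(OC)c(OC)c2)c2nnn(Cc3ccccc3)c2n1` gives 17000 nM in a functional assay on MCF7 cells (Homo sapiens) for antiproliferative activity, read by MTT assay, with a stated time of 72 h; a higher number here means a weaker inhibitor, a lower number a stronger inhibitor; compound 2 `C#CCSc1nc(N/N=C/c2c(O)ccc3ccccc23)c2nnn(Cc3ccccc3)c2n1` gives 8970 nM; compound 3 `CCCSc1nc(N/N=C/c2cc(OC)c(OC)c(OC)c2)c2nnn(Cc3ccccc3)c2n1` gives only a limit, > 64000 nM, so compound 3 sits at the limit of > 64000 nM in this assay, at which 1 of the 3 values shown sits, and no number is known for it.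

Compound 4 `COc1cc(/C=N/Nc2nc(SCc3ccccc3)nc3c2nnn3Cc2ccccc2)cc(OC)c1OC` has not been measured. Its change from compound 3 is phenyl in place of ethyl on a saturated chain carbon bound to a sulfur. Within the data shown here, the one measured step at this position, an at least 3.7-fold higher number from compound 1 to compound 3 (0.57 log units; beyond the scatter), bears on it only loosely, as it swapped a different pair of groups there. The gain or loss from a phenyl here is unsupported by any other pair, so the expectation for compound 4 stays near the limit where compound 3 stands, with wide uncertainty; the estimated step is an at least 1.6-fold lower number from compound 3 to compound 4 (0.20 log units; that floor lies within the scatter), giving an expected value of 40000 nM for compound 4, between 10000 nM and 150000 nM.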

Compound 4, half-maximal inhibitory concentration: 13500 nM
Beside the measured number, compound 4's estimate is 3.0-fold (0.47 log units) above it, and the stated range covers the measured number.
By their numbers in this assay, from the lowest: compounds 2, 4 and 1 (each within the scatter of the next). At a limit, above all of these: compound 3.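

At this place, on a saturated chain carbon bound to a sulfur, the weak reading is not shared by every replacement of ethynyl, since phenyl in place of ethyl gives an at least 4.7-fold lower number from compound 3 to compound 4 (0.67 log units; beyond the scatter). Phenyl and ethynyl cannot be told apart here, with a 1.3-fold lower number from compound 1 to compound 4 (0.10 log units; within the scatter), so among these three groups only ethyl stands apart. Compound 3 has a limit and not a number: the limit of > 64000 nM in this assay, at which 1 of the 4 values shown sits.

On these data alone, whether a longer chain, an amine or a carboxylic acid at this place would read like ethyl or like phenyl stays open. So does whether phenyl would match ethynyl with the other end of compound 2.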